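A dichlorophenyl swap on a scaffold at the assay limit

The source may hold more compounds than are shown below. What is called first, only, known or untested is meant among the compounds shown, and "the series" means these compounds.

Compound 1 `Cc1ccc(-n2nncc2CN2C(=O)C3(C(C#N)=C(N)Oc4c3c3nc5ccccc5nc3c3ccccc43)c3ccccc32)cc1C` and compound 2 `Cc1ccc(-n2nncc2CN2C(=O)C3(C(C#N)=C(N)Oc4c3c3nc5ccccc5nc3c3ccccc43)c3ccccc32)cc1Cl` share one core and differ only in the group carried on an aromatic nitrogen. In a functional assay on MCF7 cells (Homo sapiens) for antiproliferative activity, read by MTT assay, with a stated time of 48 h (on this read-out lower numbers stand for stronger inhibition and higher numbers for weaker inhibition), compound 1 reaches only a limit of the assay, > 50000 nM. In this assay compound 2 likewise gives only a limit, > 50000 nM. The step that the two limits leave unreadable from compound 1 to compound 2 therefore cannot be read in size, because the limit of > 50000 nM in this assay, at which 2 of the 2 values shown sit, places both values at the same limit. Compound 2 thus stands at that limit, with no number of its own.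

Compound 3 `N#CC1=C(N)Oc2c(c3nc4ccccc4nc3c3ccccc23)C12C(=O)N(Cc1cnnn1-c1cc(Cl)ccc1Cl)c1ccccc12` carries the change (2,5-dichlorophenyl in place of 3-chloro-4-methylphenyl on an aromatic nitrogen). Among the measured compounds shown here, the only measured step, the one from the first compound to compound 2, bears on this change, and its size is not readable, so it gives no direction for this assay; neither measured compound shows inhibition the assay can number. Compound 3 is therefore expected to give a further limit rather than a value, with an estimated step of a number no higher from compound 2 to compound 3 (the limit leaves the size open) of no readable size. The estimate for compound 3 in this assay is 50000 nM, between 20000 nM and 200000 nM.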

Compound 3, half-maximal inhibitory concentration: > 50000 nM
Compound 3: only a limit was reported; the forecaster's own chance of this, stated with the estimate: 80%; the middle value lies on the limit itself.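

Among the compounds shown here, compound 3 gives only a limit of the assay, so no step among compound 1, compound 2 and compound 3 can be read in this assay: the limit of > 50000 nM in this assay, at which 3 of the 3 values shown sit. The compounds shown leave open how strongly any of them inhibits, and whether 2,5-dichlorophenyl differs at all from 3-chloro-4-methylphenyl on the aromatic nitrogen.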